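This account rests on a few compounds, and the source may have more. Where it says the series, first, only, none or still open, it means among the compounds named here.

Two compounds of the series carry numbers in a functional assay on the whole organism (strain albino) for inhibition, with Rattus norvegicus as the target, read by paw edema, with stated times of 30 min and 1 h, at a dose of 0.28 mmol/kg by the oral route; on this read-out lower numbers stand for less inhibition and higher numbers for more inhibition at the one dose given (going by the name of the read-out). Compound 1 `C=CCn1c(SCC(=O)Nc2ccc(C(C)=O)cc2)nnc1-c1ccc(OC)c(OC)c1` gives 56% there, and compound 2 `C=CCn1c(SCC(=O)Nc2ccc(/C(C)=N/O)cc2)nnc1-c1ccc(OC)cc1` gives 54%; compound 2 holds the lower of the two numbers, yet its gap to compound 1 falls within the scatter. Compound 3 `C=CCn1c(SCC(=O)Nc2ccc(C(C)=O)cc2)nnc1-c1ccc(OC)cc1` is not yet measured. From compound 2 to compound 3 the change is a group of 3 heavy atoms (2 carbon, 1 oxygen; no ring) in place of a group of 4 heavy atoms (2 carbon, 1 nitrogen, 1 oxygen; no ring), on an aromatic carbon. Among the compounds with values here, no measured pair covers this change on its own, so the expected step is a number 1 percentage points higher from compound 2 to compound 3 (within the scatter), not beyond the scatter in either direction. Because compound 2 gives 54% and compound 1, which also carries the acetyl, gives 56%, compound 3 is expected to give about 55% in this assay, in the range 44% to 66%.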

Compound 3, a percentage reported as inhibition, in the whole organism at one dose (the size of the read-out at that dose, not a potency): 50%
For compound 3 the middle estimate is 5 percentage points above the measured one, and the stated range covers the measured number.
By their numbers in this assay, from the lowest: compounds 3, 2 and 1 (each within the scatter of the next).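

In this assay, acetyl in place of the group of 4 heavy atoms, para to a large group, gives a number 4 percentage points lower from compound 2 to compound 3 (within the scatter), and hydrogen in place of methoxy gives a number 6 percentage points lower from compound 1 to compound 3 (within the scatter). Neither change moves the read-out beyond the scatter, so at this one dose neither the group that leaves nor the methoxy shows a separable contribution. No available measurement offers an explanation for these steps.

Still open, going by these compounds, is whether an amine or a carboxylic acid in place of the acetyl would move the read-out beyond the scatter.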